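The compounds below may be only part of what the source reports. "The series", "measured", "known", "first", "only" and "open" are said of these compounds alone.

Working notes on the series. In a functional assay on PC-9 cells (Homo sapiens) for inhibition, read by MTT assay, with a stated time of 48 h, tested at 10 uM (a lower number here means less inhibition, a higher number more inhibition at the concentration tested (going by the name of the read-out)), compound 1 `COc1cc(NC(=O)Nc2cc(Nc3ccc(OC)c(C)c3)ncn2)cc(OC)c1` gives 62%, the lowest of the three numbers measured: compound 2 `CCc1ccc(Nc2cc(NC(=O)Nc3c(Cl)cccc3Cl)ncn2)cc1` gives 70.1%, within the scatter of compound 1, while compound 3 `Cc1ccc(Nc2cc(NC(=O)Nc3c(Cl)cccc3Cl)ncn2)cc1F` gives 92%, beyond the scatter above compound 1. Within the data shown here, the one step between measured compounds that differ in a single place is a number 21.9 percentage points higher from compound 2 to compound 3 (beyond the scatter); it sits at the same nitrogen on the aromatic ring that is altered here, with a fluorine-bearing methylphenyl entering.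

Compound 4 `COc1cc(NC(=O)Nc2cc(Nc3cc(C)cc(F)c3)ncn2)cc(OC)c1` differs from compound 1 by 3-fluoro-5-methylphenyl in place of 4-methoxy-3-methylphenyl on a nitrogen on an aromatic ring. Among the measured compounds shown here, no measured pair shows this exact exchange, and the two phenyl rings of compound 4 and compound 3 carry their fluorine and methyl at different positions, so the comparison is loose. For the measured compounds named here, still, the only step available points upward, and a rise of similar or somewhat smaller size is expected in this assay, namely a number 13 percentage points higher from compound 1 to compound 4 (beyond the scatter). For compound 4 the estimated value is 75%, with a range from 55% to 92%.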

Compound 4, a percentage reported as inhibition, at one concentration (the size of the read-out at that concentration, not a potency): 64.5%
Beside the measured number, compound 4's estimate is 10.5 percentage points above it; the measured number falls inside the stated range.
By their numbers in this assay, from the lowest: compounds 1, 4 and 2 (each within the scatter of the next); then compound 3.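

On the core of compound 1, 3-fluoro-5-methylphenyl in place of 4-methoxy-3-methylphenyl on a nitrogen on an aromatic ring gives a number 2.5 percentage points higher from compound 1 to compound 4 (within the scatter) in this assay, so this exchange shows no readable change at this position. A phenyl bearing fluorine and methyl at this nitrogen therefore does not bring a rise in every setting: the earlier step, a number 21.9 percentage points higher from compound 2 to compound 3 (beyond the scatter), has a different core and a different leaving group. Nothing at hand accounts for the contrast between these two steps.

Going by these compounds, it remains open whether 3-fluoro-5-methylphenyl would behave on the core of compound 3 as it does on the core of compound 1. Also open, on these data alone, is how this nitrogen responds to a phenyl carrying an amine or a carboxylic acid.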